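This account rests on a few compounds, and the source may have more. Where it says the series, first, only, none or still open, it means among the compounds named here.

The measured compounds, in a functional assay on L1210 cells (Mus musculus) for inhibition; on this read-out lower numbers stand for stronger inhibition and higher numbers for weaker inhibition:
Compound 1 `CC1(CO)OCC(n2ccc(N)nc2=O)O1` gives 50000 nM.
Compound 2 `C[C@]1(CO)OCC(n2ccc(N)nc2=O)O1` reaches only the limit of the assay, > 100000 nM.
Compound 3 `C[C@]1(CO)OCC(n2cc(F)c(N)nc2=O)O1` likewise stops at the limit of the assay, > 100000 nM.

Compound 3 therefore stands at the limit of this assay, as does compound 2; only compound 1 gives a number at all, and that number is a high one. The step from compound 3 to compound 4 `CC1(CO)OC[C@@H](n2cc(F)c(N)nc2=O)O1` is the two compounds have the same atoms and bonds; at least one stereo element is drawn with a configuration in one of them and without one in the other: 2 of 2 stereo elements differ; a stereocentre at a saturated ring carbon is drawn S in compound 3 and without a configuration in compound 4; a stereocentre at a saturated ring carbon is drawn without a configuration in compound 3 and S in compound 4. Of the measured steps only one touches a stereo element: an at least 2.0-fold higher number from compound 1 to compound 2 (0.30 log units; that floor lies within the scatter); the reading of that step rests on the limit of > 100000 nM in this assay, at which 2 of the 3 values shown sit, and on (the fact that one of compounds 1 and 2 is drawn with a defined configuration and the other without, at the place where they differ). The second measured step, a step that the two limits leave unreadable from compound 2 to compound 3, gives no size at all. Among the compounds with values here, nothing measured here shows that drawing or leaving out a configuration at the saturated ring carbons moves the read-out beyond the scatter, and the only available number, that of compound 1, lies itself not far from the limit. Compound 4 is accordingly expected to remain near the limit of this assay, with no step beyond the scatter: the estimated change is a number no higher from compound 3 to compound 4 (the limit leaves the size open). The estimate for compound 4 is 100000 nM, with an expected range from 35000 nM to 300000 nM.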

Compound 4, half-maximal inhibitory concentration: > 100000 nM
Compound 4 gave a limit, no number; the forecaster's own chance of this, stated with the estimate: 60%; the middle value sits exactly at the limit.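

In this assay, compound 3 and compound 4 both stop at the limit of the assay and give no number, so no step can be read between them. The compounds shown leave open whether the configuration drawn at the saturated ring carbons changes the inhibition of these two compounds at all, and by how much.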